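The source may hold more compounds than are shown below. What is called first, only, known or untested is meant among the compounds shown, and "the series" means these compounds.

In a functional assay on the whole organism with Canis familiaris (Canis lupus familiaris) as the target (a lower number here means that less compound is needed, a higher number that more compound is needed for the effect), compound 1 `COc1cc(Cl)ccc1-c1nc2cc[nH]cc-2n1` gives 0.23 mg/kg and compound 2 `COc1cc(C)ccc1-c1nc2cc[nH]cc-2n1` gives 0.28 mg/kg, so compound 2 stands level with compound 1 within the scatter. Compound 3 `COc1cc([N+](=O)[O-])ccc1-c1nc2cc[nH]cc-2n1` differs from compound 2 by nitro in place of methyl on an aromatic carbon, with nitro in place of methyl on an aromatic carbon. Within the data shown here, only one measured change at this place bears on it, a 1.2-fold higher number from compound 1 to compound 2 (0.09 log units; within the scatter), and that step is small. One step is thin evidence for a different group, so no shift beyond the scatter is expected. The expected step is a 1.1-fold higher number from compound 2 to compound 3 (0.03 log units; within the scatter). Compound 3 is estimated at 0.3 mg/kg, with an expected range of 0.1 mg/kg to 0.9 mg/kg.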

Compound 3, dose for half-maximal effect: 0.015 mg/kg
Compound 3: middle estimate off by 20-fold (1.30 log units), on the high side; the whole stated range lies above it.
By their numbers in this assay, from the lowest: compound 3; then compounds 1 and 2 (each within the scatter of the next).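

In this assay this aromatic carbon, meta to a methoxy group, proves sensitive to what sits on it: nitro in place of methyl gives a 19-fold lower number from compound 2 to compound 3 (1.27 log units; beyond the scatter) and nitro in place of chloro gives a 15-fold lower number from compound 1 to compound 3 (1.19 log units; beyond the scatter). Methyl and chloro stood level within the scatter, so that pair alone gave no sign of how much this place can matter.

On these data alone, whether an amine, a nitrile or a carboxylic acid here would also lower the dose stays open. No measurement at hand gives a reason for the nitro step.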